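Side chain change from compound 3 to compound 4

A few compounds are considered here, and "the series" means these few. Any claim that something is new, unique, unknown or untested is made for them only; others in the source may bear on it.

Values so far in an ADME assay on MT4 cells (Homo sapiens) for cytotoxicity, read by MTT assay, with a stated time of 5 days; on this read-out lower numbers stand for higher toxicity in this test and higher numbers for lower toxicity in this test:
- compound 1 `Cc1cc(/C=C/C#N)cc(C)c1Oc1cc(NCCN(C)C)nc(Nc2ccc(C#N)cc2)c1` gives 4270 nM in this test
- compound 2 `Cc1cc(/C=C/C#N)cc(C)c1Oc1cc(Cl)nc(Nc2ccc(C#N)cc2)n1` gives 4310 nM in this test
- compound 3 `C=CCNc1cc(Oc2c(C)cc(/C=C/C#N)cc2C)cc(Nc2ccc(C#N)cc2)n1` gives 82100 nM in this test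

Compound 3 has the highest of the three numbers, and the values of compound 1 and compound 2 both lie well beneath it.

The next compound is compound 4 `Cc1cc(/C=C/C#N)cc(C)c1Oc1cc(NCCN2CCN(C)CC2)nc(Nc2ccc(C#N)cc2)c1`, which differs from compound 3 in one place: (4-methylpiperazin-1-yl)methyl in place of vinyl on a saturated chain carbon bound to a nitrogen on an aromatic ring. In words, (4-methylpiperazin-1-yl)methyl stands in place of vinyl on a saturated chain carbon bound to a nitrogen on an aromatic ring.

Going by the values given here, one measured step bears on this change: a 19-fold higher number from compound 1 to compound 3 (1.28 log units; beyond the scatter), with vinyl in place of (dimethylamino)methyl at that same place. The change to compound 4 runs the opposite way, leaving vinyl for another amine-bearing group. That entering group has not been measured on this core, so compound 1 is a guide and not a direct match. A large step towards a lower number is therefore expected in this assay, close in size to the step above. The estimated step is a 16-fold lower number from compound 3 to compound 4 (1.22 log units; beyond the scatter) on this read-out. The expected value of compound 4 is 5000 nM within an estimated range of 1500 nM to 20000 nM on this read-out.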

Compound 4, half-maximal cytotoxic concentration: 7960 nM
Compound 4: the middle estimate sits 1.6-fold (0.20 log units) below what was measured; the measured number falls inside the stated range.
By their numbers in this assay, from the lowest: compounds 1, 2 and 4 (each within the scatter of the next); then compound 3.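

In this assay, replacing the allyl chain with 2-(4-methylpiperazin-1-yl)ethyl gives a 10-fold lower number from compound 3 to compound 4 (1.01 log units; beyond the scatter), so the high number of compound 3 is now set against two amine-bearing chains, not one, and both lie far beneath it. The new comparison between those chains gives a 1.9-fold higher number from compound 1 to compound 4 (0.27 log units; within the scatter), which means that 4-methylpiperazin-1-yl and dimethylamino at the end of the chain cannot be told apart in this assay, even though the former adds a six-membered non-aromatic ring with 2 hetero atoms. The data at hand offer no explanation for the large gap between the allyl chain and the amine-bearing chains.

The compounds shown leave open whether the terminal amine nitrogen or some other feature of these longer chains separates compound 1 and compound 4 from compound 3, a question that a plain butyl chain or a 2-hydroxyethyl chain at the same place would address. They also leave open how a 2-(morpholin-4-yl)ethyl group, or a longer chain carrying the same dimethylamino or 4-methylpiperazin-1-yl end, would read on the shared core.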